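This account rests on a few compounds, and the source may have more. Where it says the series, first, only, none or still open, it means among the compounds named here.

In an ADME assay on BV-2 cells (Mus musculus) for cytotoxicity, with a stated time of 24 h, tested at 50 uM (a higher number here means a weaker effect of the compound at the concentration tested, a lower number a stronger effect), compound 1 `COc1cccc(S(=O)(=O)/C=C/c2ccccn2)c1` gives 98.9%, the highest of the three numbers measured, although the number for compound 2 sits within the scatter of it. Compound 2 `COc1cccc(S(=O)(=O)/C=C/c2cccc(Cl)n2)c1` gives 89.3% and compound 3 `COc1cccc(S(=O)(=O)/C=C/c2ccc(Cl)cn2)c1` gives 67.6%. Compound 4 `COc1cccc(S(=O)(=O)/C=C/c2ncccc2Cl)c1` has not been measured; it differs from compound 1 by chloro in place of hydrogen on an aromatic carbon. Among the compounds with values here, two measured steps bear on this change, each a chloro in place of hydrogen on an aromatic carbon of the shared core, though at other places: a number 9.6 percentage points lower from compound 1 to compound 2 (within the scatter) and a number 31.3 percentage points lower from compound 1 to compound 3 (beyond the scatter). Both point downward, one within the scatter and one beyond it. A downward step of middling size is therefore expected, a number 16.9 percentage points lower from compound 1 to compound 4 (beyond the scatter). Compound 4 is estimated at 82%, with a range from 60% to 100%.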

Compound 4, a percentage reported as activity, at one concentration (the size of the read-out at that concentration, not a potency): 82.2%
Compound 4: middle estimate off by 0.2 percentage points, on the low side; the measured number falls inside the stated range.
By their numbers in this assay, from the lowest: compound 3; then compounds 4, 2 and 1 (each within the scatter of the next, the first and the last beyond it).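

In this assay chloro on an aromatic carbon ortho to a large group and two atoms from the ring nitrogen gives a number 16.7 percentage points lower from compound 1 to compound 4 (beyond the scatter) and so counts as a modest but real change at this position. Two of the three chloro placements shown, those in compound 3 and compound 4, now step beyond the scatter, while the step to compound 2 stays within it. Nothing measured here explains this position's result. Going by these compounds, whether a fluoro or an amine at this position would shift the number as chloro does remains open.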